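Replacing the phenyl of compound 1 with isopropyl

This account rests on a few compounds, and the source may have more. Where it says the series, first, only, none or still open, it means among the compounds named here.

In an assay on isolated protein for inhibition of proto-oncogene tyrosine-protein kinase receptor Ret (Homo sapiens), read by radiometric assay and 33P incorporation, in the presence of a further agent that is not named here (on this read-out higher numbers stand for weaker inhibition and lower numbers for stronger inhibition), two compounds have been measured. Compound 1 `CC(C)n1nc(-c2cc(-c3ccccc3)on2)c(C(N)=O)c1N` gives 236 nM. Compound 2 `CC(C)n1nc(-c2cc(-c3cccnc3)on2)c(C(N)=O)c1N` gives 3400 nM.

Going by the values given here, compound 1 stands lowest of the two numbers, and the single measured step, a 14-fold higher number from compound 1 to compound 2 (1.16 log units; beyond the scatter), is large. Compound 3 `CC(C)c1cc(-c2nn(C(C)C)c(N)c2C(N)=O)no1` differs from compound 1 by isopropyl in place of phenyl on an aromatic carbon. Among the compounds with values here, only that one step bears on this change, and it shows that altering the phenyl weakens inhibition in this assay; isopropyl is a further departure, so a step beyond the scatter toward a higher number is expected, estimated as a 6.4-fold higher number from compound 1 to compound 3 (0.80 log units; beyond the scatter). Compound 3 is therefore estimated at 1500 nM, in the range 400 nM to 6000 nM.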

Compound 3, half-maximal inhibitory concentration: 1260 nM
Compound 3: the middle estimate sits 1.2-fold (0.08 log units) above what was measured, within the range that was stated.
By their numbers in this assay, from the lowest: compound 1; then compound 3; then compound 2.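

Isopropyl, which brings no ring, still gives a measurable number on this carbon next to the ring oxygen, though at a cost to inhibition: a 5.3-fold higher number from compound 1 to compound 3 (0.73 log units; beyond the scatter). Removing the ring costs less than exchanging phenyl for pyridin-3-yl, as a 2.7-fold lower number from compound 2 to compound 3 (0.43 log units; beyond the scatter) shows, so among these groups the loss does not simply track the absence of an aromatic ring. Nothing available explains this order.

The compounds shown leave open how methyl, cyclohexyl or an amine on this carbon would compare with phenyl. They also leave open whether any group here could give a lower number than compound 1.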